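The compounds below may be only part of what the source reports. "The series", "measured", "known", "first", "only" and "open" are said of these compounds alone.

Three compounds share one core and were tested in an ADME assay on Vero cells (Chlorocebus sabaeus) for cytotoxicity, read by neutral red uptake, tested at 1575 ug/mL; a higher number here means a weaker effect of the compound at the concentration tested, a lower number a stronger effect. In this assay compound 1 `COc1ccc(C2SCC(=O)N2CCN2CCCCC2)cc1` gives 11%. Compound 2 `O=C1CSC(c2cccc(Cl)c2)N1CCN1CCCCC1` gives 20%, and compound 3 `O=C1CSC(c2ccc(O)cc2)N1CCN1CCCCC1` gives 12%. On these numbers compound 3 stands second highest of three, with compound 1 nearest and compound 2 furthest. Both steps leading to it stay within the scatter: a number 1 percentage points higher from compound 1 to compound 3 (within the scatter) and a number 8 percentage points lower from compound 2 to compound 3 (within the scatter). Compound 4 `O=C1CSC(c2ccc([N+](=O)[O-])cc2)N1CCN1CCCCC1` has not yet been measured and differs from compound 3 in one place: nitro in place of hydroxy on an aromatic carbon. Within the data shown here, no measured step involves a nitro group, but both known changes on the aromatic ring stayed within the scatter, so a step of about a number 2 percentage points higher from compound 3 to compound 4 (within the scatter) is expected in this assay, none beyond the scatter. Compound 4 is therefore estimated at 14%, between 4% and 28%.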

Compound 4, a percentage reported as activity, at one concentration (the size of the read-out at that concentration, not a potency): 15%
Compound 4: middle estimate off by 1 percentage points, on the low side, and the stated range covers the measured number.
By their numbers in this assay, from the lowest: compounds 1, 3, 4 and 2 (each within the scatter of the next).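

In this assay nitro in place of hydroxy gives a number 3 percentage points higher from compound 3 to compound 4 (within the scatter) and nitro in place of methoxy gives a number 4 percentage points higher from compound 1 to compound 4 (within the scatter) on this aromatic carbon, para to a large group. The position therefore tolerates a group with no hydrogen-bond donor and more heavy atoms without leaving the scatter, which compounds 1 and 3 alone could not show. No measurement at hand accounts for this result. The compounds shown leave open whether an amine or a carboxylic acid on this carbon would also stay within the scatter, and whether changes to the shared core would go beyond it.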